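The source may hold more compounds than are shown below. What is called first, only, known or untested is meant among the compounds shown, and "the series" means these compounds.

Compound 1 `O=S(=O)(c1cc(Cl)cc(Cl)c1)c1cnc2c(F)cccc2c1-c1cccc(F)c1` stands second highest of the three numbers in an ADME assay on microsomes from liver (Homo sapiens) for metabolic stability, tested at 2.5 uM (a lower number here means slower removal, a higher number faster removal of the compound), where compound 1 gives 1.08 mL/min. Compound 2 `O=S(=O)(c1ccc(F)c(Cl)c1)c1cnc2c(F)cccc2c1-c1cccc(F)c1` gives 1.23 mL/min, and the step of a 1.1-fold higher number from compound 1 to compound 2 (0.06 log units; within the scatter) is within the scatter. Compound 3 `N#Cc1cccc(S(=O)(=O)c2cnc3c(F)cccc3c2-c2cccc(F)c2)c1` gives 0.34 mL/min, reached by a 3.2-fold lower number from compound 1 to compound 3 (0.50 log units; beyond the scatter) and by a 3.6-fold lower number from compound 2 to compound 3 (0.56 log units; beyond the scatter). Compound 4 `COc1ccc(-c2c(S(=O)(=O)c3cc(Cl)cc(Cl)c3)cnc3c(F)cccc23)cc1` is not yet measured; it differs from compound 1 by 4-methoxyphenyl in place of 3-fluorophenyl on an aromatic carbon. Within the data shown here, every measured step alters the group on the sulfonyl sulfur and none alters the aryl on the aromatic carbon of the shared core, so no step bears directly on this change. The expected outcome is a number near that of compound 1, with a wide range in either direction. For compound 4 the estimate in this assay is 1.3 mL/min, between 0.5 mL/min and 3.2 mL/min, meaning a step of a 1.2-fold higher number from compound 1 to compound 4 (0.08 log units; within the scatter) that is expected to fall within the scatter.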

Compound 4, intrinsic clearance in a liver preparation (reported as CLH), per the amount of preparation that the assay uses: 2.11 mL/min
Beside the measured number, compound 4's estimate is 1.6-fold (0.21 log units) below it; low and high end bracket the measured number.
By their numbers in this assay, from the lowest: compound 3; then compounds 1, 2 and 4 (each within the scatter of the next).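

Replacing 3-fluorophenyl with 4-methoxyphenyl on the aromatic carbon opposite the ring nitrogen gives a 2.0-fold higher number from compound 1 to compound 4 (0.29 log units; within the scatter) in this assay, the first read at this position, and it stays within the scatter. This single change therefore shows no clear effect on the read-out here, although the size of the step keeps a real effect from being excluded. No measurement shown gives a reason for this step. One swap cannot separate removing the fluorine from adding the methoxy group. As far as these compounds go, whether an amine or a carboxylic acid on this aryl ring would move the number beyond the scatter remains open.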